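From Amino to Hydroxy on an Aromatic Carbon

A few compounds are considered here, and "the series" means these few. Any claim that something is new, unique, unknown or untested is made for them only; others in the source may bear on it.

In a functional assay on DU-145 cells (Homo sapiens) for cytotoxicity, read by trypan blue exclusion, with a stated time of 96 h (a higher number here means a weaker inhibitor, a lower number a stronger inhibitor), compound 1 `COc1cc(OC)c(/C=C/S(=O)(=O)Nc2ccc(OC)c(O)c2)c(OC)c1` gives 30 nM, compound 2 `COc1ccc(NS(=O)(=O)/C=C/c2c(OC)cc(OCCCC(=O)O)cc2OC)cc1[N+](=O)[O-]` gives 100000 nM and compound 3 `COc1ccc(NS(=O)(=O)/C=C/c2c(OC)cc(OCCCC(=O)O)cc2OC)cc1N` gives 10000 nM. Compound 3 thus holds the second highest of the three numbers, with both gaps beyond the scatter. Compound 4 `COc1ccc(NS(=O)(=O)/C=C/c2c(OC)cc(OCCCC(=O)O)cc2OC)cc1O` carries hydroxy in place of amino, ortho to a methoxy group: hydroxy in place of amino on an aromatic carbon. Going by the values given here, the one measured step at this place is a 10-fold lower number from compound 2 to compound 3 (1.00 log units; beyond the scatter), which swaps nitro for amino and so bears only indirectly. Compound 1 also holds the 3-hydroxy-4-methoxyphenyl group, but differs elsewhere. Only a small move toward a lower number is therefore expected, a 2.0-fold lower number from compound 3 to compound 4 (0.30 log units; within the scatter). For compound 4 the estimated value is 5000 nM, with an expected range of 1000 nM to 25000 nM.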

Compound 4, half-maximal inhibitory concentration: 10000 nM
The estimate for compound 4 lay 2.0-fold (0.30 log units) below the measured number, and the stated range covers the measured number.
By their numbers in this assay, from the lowest: compound 1; then compounds 3 and 4 (each within the scatter of the next); then compound 2.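

In this assay, the change from amino to hydroxy gives no change at the digits printed from compound 3 to compound 4 (within the scatter), so this position does not separate these two groups on this scaffold, while nitro differs from hydroxy by a 10-fold lower number from compound 2 to compound 4 (1.00 log units; beyond the scatter). The 3-hydroxy-4-methoxyphenyl group does not by itself secure a low number: adding the 2-carboxyethyl group goes with a 330-fold higher number from compound 1 to compound 4 (2.52 log units; beyond the scatter). Nothing measured here accounts for either result.

Still open, going by these compounds, is whether a methyl ester or an amide in place of the carboxylic acid would bring the number closer to that of compound 1. Also open, on these data alone, is whether fluorine or a methyl group at this position would depart from hydroxy and amino.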